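A few compounds are considered here, and "the series" means these few. Any claim that something is new, unique, unknown or untested is made for them only; others in the source may bear on it.

Measured so far:
compound 1 `CN1CCN(c2nc(Cl)nc3c2ncn3Cc2ccc(C(=O)Nc3ccccc3N)cc2)CC1` — 55.1%
compound 2 `Nc1ccccc1NC(=O)/C=C/c1ccc(Cn2cnc3c(Nc4cccc(Cl)c4)nc(Cl)nc32)cc1` — 29.4%
compound 3 `Nc1ccccc1NC(=O)/C=C/c1ccc(Cn2cnc3c(NC4CCCCC4)nc(Cl)nc32)cc1` — 24.9%

In a functional assay on NCI-H460 cells (Homo sapiens) for antiproliferative activity, read by CCK-8 assay, with a stated time of 72 h, tested at 8 uM (on this read-out higher numbers stand for a stronger effect at the one concentration tested and lower numbers for a weaker effect), compound 3 gives 24.9%, at the low end of the three numbers. Compound 1 gives 55.1%, a gap beyond the scatter. For the measured compounds named here, the one measured step of this kind, a number 4.5 percentage points lower from compound 2 to compound 3 (within the scatter), exchanged a cyclohexyl for a 3-chlorophenyl at the same place and stayed within the scatter.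

Compound 4 `Nc1ccccc1NC(=O)/C=C/c1ccc(Cn2cnc3c(Nc4ccccc4)nc(Cl)nc32)cc1` differs from compound 3 by phenyl in place of cyclohexyl on a nitrogen on an aromatic ring. Going by the values given here, only that step bears on it, and it was small, so no step beyond the scatter is expected: a number 2.1 percentage points higher from compound 3 to compound 4 (within the scatter). Compound 4 is therefore estimated at 27%, within a range from 15% to 40%.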

Compound 4, a percentage reported as inhibition, at one concentration (the size of the read-out at that concentration, not a potency): 28.7%
The estimate for compound 4 lay 1.7 percentage points below the measured number, and the stated range covers the measured number.
By their numbers in this assay, from the lowest: compounds 3, 4 and 2 (each within the scatter of the next); then compound 1.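

The change from cyclohexyl to phenyl on this nitrogen gave a number 3.8 percentage points higher from compound 3 to compound 4 (within the scatter) in this assay, and removing the chloro from the 3-chlorophenyl group gave a number 0.7 percentage points lower from compound 2 to compound 4 (within the scatter). Compounds 2, 3 and 4 therefore cannot be told apart in this read-out, so these three groups at this position read alike. No measured evidence accounts for this.

As far as these compounds go, whether a morpholine, a carboxylic acid or a longer chain on this nitrogen would shift the number remains open. Also open, from the compounds shown here alone, is what sets compound 1 apart, as it differs from the others in more than one place.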